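The source may report more compounds than this note shows. Statements on the series, on what has been measured and on what is new or still open speak of the compounds shown alone.

Compound 2 `Cc1nc(S(C)(=O)=O)ccc1Oc1ncnc(OC2CCN(C(=O)C(C)(C)F)CC2)c1F` and compound 1 `Cc1nc(S(C)(=O)=O)ccc1Oc1ncnc(OC2CCN(C(=O)O[C@H](C)C(F)(F)F)CC2)c1F` share a core and differ only in the group on the carbonyl carbon of the piperidine nitrogen. In a functional assay on isolated protein for inhibition of Glucose-dependent insulinotropic receptor (Homo sapiens), read by HTRF and cAMP accumulation (a lower number here means that less compound is needed, a higher number that more compound is needed for the effect), compound 2 gives 76.3 nM, the highest of the two numbers measured; in this assay compound 1 gives 9.2 nM. For the measured compounds named here, the one measured step, an 8.3-fold higher number from compound 1 to compound 2 (0.92 log units; beyond the scatter), exchanges an alkoxy group for an alkyl group on that carbonyl carbon.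

Compound 3 `Cc1nc(S(C)(=O)=O)ccc1Oc1ncnc(OC2CCN(C(=O)C3(C)CC3)CC2)c1F` is not yet measured. It differs from compound 2 in 1-methylcyclopropyl in place of 1-fluoro-1-methylethyl on a carbonyl carbon. Going by the values given here, no measured step covers this exchange of one alkyl group for another: the step from compound 1 to compound 2 swaps a carbamate for an amide, which is a different kind of change, so it only shows that this position can move the number substantially. Since both groups entering and leaving are small alkyl groups of equal heavy-atom count, compound 3 is expected to stay close to compound 2, with the step of a 1.3-fold lower number from compound 2 to compound 3 (0.10 log units; within the scatter) estimated to lie within the scatter. Compound 3 is therefore estimated at 60 nM, in a range from 15 nM to 250 nM.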

Compound 3, half-maximal effective concentration: 761 nM
For compound 3 the middle estimate is 13-fold (1.10 log units) below the measured one; the whole stated range lies below it.
By their numbers in this assay, from the lowest: compound 1; then compound 2; then compound 3.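

In this assay the exchange of 1-fluoro-1-methylethyl for 1-methylcyclopropyl on this carbonyl carbon gives a 10-fold higher number from compound 2 to compound 3 (1.00 log units; beyond the scatter) and so is not a neutral swap, even though the two groups have the same heavy-atom count and neither has a hydrogen-bond donor or acceptor. Together with an 83-fold higher number from compound 1 to compound 3 (1.92 log units; beyond the scatter) and the smaller 8.3-fold higher number from compound 1 to compound 2 (0.92 log units; beyond the scatter), this shows that the position responds both to the change from alkoxy to alkyl and to the choice of alkyl group, with the number rising from compound 1 through compound 2 to compound 3. Nothing available explains why the all-carbon group gives the higher number.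

The exchange removes the fluorine and adds the three-membered ring in a single step, so the shown compounds cannot separate the two changes, and it remains open how a plain tert-butyl group or a 1-fluorocyclopropyl group would read on the same carbonyl carbon. Also open, as far as these compounds go, is whether a simpler alkoxy group, such as ethoxy or isopropoxy, would stay as close to compound 1 as the trifluoromethyl-bearing carbamate allows.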